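This account rests on a few compounds, and the source may have more. Where it says the series, first, only, none or still open, it means among the compounds named here.

Measured so far:
- compound 1 `O=C(N/N=C/c1ccccc1Cl)c1cnccn1`: 69%
- compound 2 `O=C(N/N=C/c1cccc(Br)c1)c1cnccn1`: 93%

In an ADME assay on J774 cells (Mus musculus) for cytotoxicity, read by MTT assay, with a stated time of 48 h, tested at 150 ug/mL (on this read-out higher numbers stand for a weaker effect at the one concentration tested and lower numbers for a stronger effect), compound 1 gives 69%, the lower of the two numbers, and compound 2 gives 93%, a number higher by more than the usual scatter. Compound 3 `COc1ccccc1/C=N/NC(=O)c1cnccn1` has not yet been measured in this assay. It differs from compound 1 by methoxy in place of chloro on an aromatic carbon. Within the data shown here, no measured pair shows this change, so its effect is unknown. Given that compound 2 gives 93% while compound 1 gives 69%, a small rise is expected for the step of a number 11 percentage points higher from compound 1 to compound 3 (beyond the scatter). For compound 3 the expected value is 80%, between 55% and 98%.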

Compound 3, a percentage reported as activity, at one concentration (the size of the read-out at that concentration, not a potency): 97%
For compound 3 the middle estimate is 17 percentage points below the measured one; measured number inside the range.
By their numbers in this assay, from the lowest: compound 1; then compounds 2 and 3 (each within the scatter of the next).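

Placing methoxy instead of chloro on this aromatic carbon, ortho to a large group, gives a number 28 percentage points higher from compound 1 to compound 3 (beyond the scatter) in this assay, so this position does respond to the change. Here, a higher number means a weaker effect at the one concentration tested, so the effect is stronger with chloro than with methoxy. No measurement here explains why the swap has this effect.

Still open, going by these compounds, is how an amine, a carboxylic acid or a longer chain would behave on this same carbon. A single swap also leaves open whether methoxy in place of chloro would give a similar step elsewhere on the ring.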